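The source may report more compounds than this note shows. Statements on the series, on what has been measured and on what is new or still open speak of the compounds shown alone.

Measured so far in a functional assay on MT4 cells (Homo sapiens) for antiproliferative activity, read by MTT assay, with a stated time of 96 h; a lower number here means a stronger inhibitor, a higher number a weaker inhibitor:
compound 1 `CCCc1ccc(N2C(=O)NC3(CSC4=C3C(=O)c3ncccc3C4=O)C2=O)cc1` gives 1 nM
compound 2 `O=C1NC(=O)C2(CSC3=C2C(=O)c2ncccc2C3=O)N1` gives 130 nM; 120 nM; 130 nM (3 entries)
compound 3 `O=C1C2=C(C(=O)c3ncccc31)C1(CS2)NC(=O)N(c2ccc(Cl)cc2)C1=O` gives 10 nM

Within the data shown here, compound 3 stands highest of the two single numbers in this assay ; its nearest neighbour is compound 1, and the one measured step, a 10-fold higher number from compound 1 to compound 3 (1.00 log units; beyond the scatter), separates them. Compound 2 carries no aryl group on the shared core and is known only through several entries, (the several entries of compound 2 in this assay, 130 nM; 120 nM; 130 nM (3 entries)), so it gives no single number to rank against.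

Compound 4 `O=C1C2=C(C(=O)c3ncccc31)C1(CS2)NC(=O)N(c2ccc([N+](=O)[O-])cc2)C1=O` is next. It differs from compound 3 in one place: nitro in place of chloro on an aromatic carbon. Among the measured compounds shown here, no measured step covers this exchange; the only step available, a 10-fold higher number from compound 1 to compound 3 (1.00 log units; beyond the scatter), shows that replacing one group on that aromatic carbon by another can move this assay by a modest amount. Nitro in place of chloro is a change of the same kind, so a step of modest size is expected, with the direction open, and a value close to compound 3 is as likely as a shift beyond the scatter.

Compound 4 is therefore expected near 20 nM, in the range 5 nM to 80 nM, which means an expected step of a 2.0-fold higher number from compound 3 to compound 4 (0.30 log units; within the scatter).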

Compound 4, half-maximal inhibitory concentration: 8 nM
The estimate for compound 4 lay 2.5-fold (0.40 log units) above the measured number, within the range that was stated.
By their numbers in this assay, from the lowest: compound 1; then compounds 4 and 3 (each within the scatter of the next).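

Nitro in place of chloro on this aromatic carbon, para to a large group, gives a 1.3-fold lower number from compound 3 to compound 4 (0.10 log units; within the scatter) in this assay, so the two groups cannot be told apart in this read-out, a point the earlier compounds could not settle. The propyl compound stays separate from both, with an 8.0-fold higher number from compound 1 to compound 4 (0.90 log units; beyond the scatter) alongside a 10-fold higher number from compound 1 to compound 3 (1.00 log units; beyond the scatter), and both steps lie beyond the scatter, so at this position the exchange of propyl moves the number while the exchange of chloro for nitro does not. Nothing shown here gives a cause for either observation.

From the compounds shown here alone, it remains open whether the low number of compound 1 belongs to propyl alone or extends to a longer chain such as butyl, and whether an amine or a carboxylic acid on the same carbon would fall with chloro and nitro or with propyl. These comparisons also vary only this one aromatic carbon, so they say nothing about changes to the rest of the shared core.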